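A few compounds are considered here, and "the series" means these few. Any claim that something is new, unique, unknown or untested is made for them only; others in the source may bear on it.

Measured compounds:
compound 1, `COc1cc(/C=C/C(=O)c2cccc(-n3cc(-c4ccccc4)[nH]c3=O)c2)ccc1O`, 1550 nM
compound 2, `O=C(/C=C/c1cccc(O)c1)c1cccc(-n2cc(-c3ccccc3)[nH]c2=O)c1`, 2470 nM

Going by the values given here, compound 2 gives the highest of the two numbers in a functional assay on MCF7 cells (Homo sapiens) for inhibition; on this read-out lower numbers stand for stronger inhibition of growth and higher numbers for weaker inhibition of growth; its nearest neighbour is compound 1, and the only measured step, a 1.6-fold higher number from compound 1 to compound 2 (0.20 log units; within the scatter), lies within the scatter. Among the compounds with values here, on the numbers so far the two compounds are therefore indistinguishable in this assay.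

Compound 3, `O=C(/C=C/c1cccc(O)c1)c1cccc(-n2cc(-c3ccc(Cl)cc3)[nH]c2=O)c1`, is not yet measured. It differs from compound 2 by chloro in place of hydrogen on an aromatic carbon. Within the data shown here, the phenyl on the shared core is untouched in the step from compound 1 to compound 2, which changes only the hydroxyphenyl end of the chain; no measured step therefore bears on the chloro substitution, and nothing in the data shows how this ring tolerates a substituent. Among the measured compounds shown here, with no relevant precedent, the default expectation is a step of no more than the scatter in either direction, so compound 3 is expected to give about the same number as compound 2, with a range wide enough to cover a modest move either way.

Compound 3 is estimated at 2200 nM (range 800 nM to 6000 nM), which amounts to an expected step of a 1.1-fold lower number from compound 2 to compound 3 (0.05 log units; within the scatter).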

Compound 3, concentration for 50% growth inhibition: 1270 nM
Compound 3: the middle estimate sits 1.7-fold (0.24 log units) above what was measured, and the stated range covers the measured number.
By their numbers in this assay, from the lowest: compounds 3, 1 and 2 (each within the scatter of the next).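

The phenyl on the shared core now has its first measured substitution: in this assay the change from phenyl to 4-chlorophenyl gives a 1.9-fold lower number from compound 2 to compound 3 (0.29 log units; within the scatter) and so leaves the read-out within the scatter. A chloro para to a large group on this ring is therefore accepted in this assay, something the earlier step could not show, as it changed only the hydroxyphenyl end of the chain; a single step of this size cannot be read as a gain in inhibition of growth. Nothing measured on this series accounts for where the number of compound 3 falls.

Going by these compounds, whether an amine, a carboxylic acid or a trifluoromethyl in place of the chloro would also stay within the scatter of compound 3 remains open, as does the effect of a chloro on another carbon of this ring. Also open is whether the chloro step carries over to the 4-hydroxy-3-methoxyphenyl end of compound 1, as the step is shown with the 3-hydroxyphenyl end only.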